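This account rests on a few compounds, and the source may have more. Where it says the series, first, only, none or still open, it means among the compounds named here.

In a physicochemical assay for lipophilicity, measured as octanol-water partition (on this read-out lower numbers stand for lower lipophilicity and higher numbers for higher lipophilicity), compound 3 (`CN(C)c1ccc(/C=N/c2ccccc2C(=O)NNc2ccnc3cc(Cl)ccc23)cc1`) stands lowest of the three measured compounds at 5.03, while compound 1 (`O=C(NNc1ccnc2cc(Cl)ccc12)c1ccccc1/N=C/c1ccc(Cl)cc1Cl`) gives 6.22 and compound 2 (`O=C(NNc1ccnc2cc(Cl)ccc12)c1ccccc1/N=C/c1ccc(Cl)c(Cl)c1`) gives 6.22. The structural change from compound 3 to compound 4 (`O=C(NNc1ccnc2cc(Cl)ccc12)c1ccccc1/N=C/c1cc2ccccc2[nH]c1=O`) is a group of 11 heavy atoms (9 carbon, 1 nitrogen, 1 oxygen; one six-membered aromatic ring of carbon only, one six-membered aromatic ring with 1 hetero atom) in place of a group of 9 heavy atoms (8 carbon, 1 nitrogen; one six-membered aromatic ring of carbon only), on a carbon with a double bond to nitrogen. Three measured steps replace a group on that same kind of carbon: no change at the digits printed from compound 1 to compound 2 (within the scatter), then a number 1.19 log units lower from compound 1 to compound 3 (beyond the scatter), and a number 1.19 log units lower from compound 2 to compound 3 (beyond the scatter). None of them brings in a group like the entering one, so they offer only a loose guide. The expected step in this assay is modest and downward, a number 0.38 log units lower from compound 3 to compound 4 (beyond the scatter). The estimate for compound 4 is 4.65, with an expected range from 4 to 5.3.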

Compound 4, partition coefficient: 4.65
For compound 4 middle estimate and measured number coincide at the digits printed; low and high end bracket the measured number.
By their numbers in this assay, from the lowest: compound 4; then compound 3; then compounds 1 and 2 (each within the scatter of the next).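

In this assay, within the data shown here, the entering group, with a hydrogen-bond donor where 4-(dimethylamino)phenyl has none, gives a number 0.38 log units lower from compound 3 to compound 4 (beyond the scatter), so this position can go lower than the earlier compounds showed. Set against the two dichlorophenyl groups, the same change gives a number 1.57 log units lower from compound 2 to compound 4 (beyond the scatter) and a number 1.57 log units lower from compound 1 to compound 4 (beyond the scatter), the largest steps yet seen on this carbon. Nothing shown here accounts for these steps.

The compounds shown leave open where a simple unsubstituted phenyl would stand on this carbon. They also leave open whether a group carrying a carboxylic acid or an aliphatic amine would give a still lower number.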